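Anilinoquinoline series: removing one chloro from compound 3

This account rests on a few compounds, and the source may have more. Where it says the series, first, only, none or still open, it means among the compounds named here.

Three compounds of the shared core are measured in a functional assay on cells (Panel melanoma (Carcinoma cell lines), Homo sapiens) for inhibition, read by sulforhodamine B assay, with a stated time of 48 h; a higher number here means a weaker inhibitor of growth, a lower number a stronger inhibitor of growth. Compound 1 `CN1CCN(CCCOc2cccc3nc(Nc4ccc(Cl)c(F)c4)ccc23)CC1` gives 1820 nM. Compound 2 `CC(C)c1ccc(Nc2ccc3c(OCCCN4CCN(C)CC4)cccc3n2)cc1` gives 6620 nM. Compound 3 `CN1CCN(CCCOc2cccc3nc(Nc4cc(Cl)cc(Cl)c4)ccc23)CC1` gives 1800 nM, the lowest of the three numbers, with compound 1 within the scatter of it and compound 2 further off. The measured steps run a 3.6-fold higher number from compound 1 to compound 2 (0.56 log units; beyond the scatter), a 1.0-fold lower number from compound 1 to compound 3 (0.00 log units; within the scatter) and a 3.7-fold lower number from compound 2 to compound 3 (0.57 log units; beyond the scatter).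

Compound 4 `CN1CCN(CCCOc2cccc3nc(Nc4cccc(Cl)c4)ccc23)CC1` differs from compound 3 by hydrogen in place of chloro on an aromatic carbon, the change sitting meta to a chloro group on the six-membered carbon ring. Among the measured compounds shown here, no measured step removes a halogen outright; the nearest guide is a 1.0-fold lower number from compound 1 to compound 3 (0.00 log units; within the scatter), where rearranging halogens on that ring left this assay unchanged, while the larger swap in a 3.6-fold higher number from compound 1 to compound 2 (0.56 log units; beyond the scatter) moved it only modestly. A step of at most modest size, if any, is therefore expected in this assay for compound 4, most likely toward a slightly higher number, as a 1.4-fold higher number from compound 3 to compound 4 (0.14 log units; within the scatter). The estimate for compound 4 is 2500 nM, within 1200 nM to 5500 nM.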

Compound 4, concentration for 50% growth inhibition: 1760 nM
The estimate for compound 4 lay 1.4-fold (0.15 log units) above the measured number; measured number inside the range.
By their numbers in this assay, from the lowest: compounds 4, 3 and 1 (each within the scatter of the next); then compound 2.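

In this assay, the step of a 1.0-fold lower number from compound 3 to compound 4 (0.01 log units; within the scatter) shows that, at this position on the 3,5-dichlorophenyl, chloro and hydrogen are not told apart, so the 3-chlorophenyl compound keeps the standing of the dichloro compound. The steps of a 1.0-fold lower number from compound 1 to compound 4 (0.01 log units; within the scatter) and a 3.8-fold lower number from compound 2 to compound 4 (0.58 log units; beyond the scatter) place the single chloro with the 4-chloro-3-fluorophenyl compound and leave only the 4-isopropylphenyl compound set apart beyond the scatter. Nothing available gives a reason for this insensitivity to the second chloro.

Still open, as far as these compounds go, is what the remaining chloro contributes, which a plain phenyl, or a methoxy or nitrile in its place, would address. Also open, from the compounds shown here alone, is how far these readings depend on the side chain, where a shorter chain than the propoxy linker to the methylpiperazine would be informative.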